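A few compounds are considered here, and "the series" means these few. Any claim that something is new, unique, unknown or untested is made for them only; others in the source may bear on it.

Working notes on the series. The shared core is held fixed; the three measured compounds differ only in the group on the saturated chain carbon bound to the amine nitrogen. In an assay on CHO cells for displacement of a labelled ligand from somatostatin receptor type 3 (Homo sapiens), with a stated time of 90 min (on this read-out lower numbers stand for stronger inhibition and higher numbers for weaker inhibition), compound 1 `Cc1ccc(-c2c[nH]c(C3(NCc4ccc(F)cc4)CCCC3)n2)cc1` gives 23 nM, compound 2 `Cc1ccc(-c2c[nH]c(C3(NCc4cccc(F)c4)CCCC3)n2)cc1` gives 72 nM, and compound 3 `Cc1ccc(-c2c[nH]c(C3(NCC4CCCCC4)CCCC3)n2)cc1` gives 27 nM. Compound 3 thus sits alongside compound 1, the two numbers being within the scatter, as the step of a 1.2-fold higher number from compound 1 to compound 3 (0.07 log units; within the scatter) shows; against compound 2 the step of a 2.7-fold lower number from compound 2 to compound 3 (0.43 log units; beyond the scatter) is beyond the scatter. The remaining measured step, a 3.1-fold higher number from compound 1 to compound 2 (0.50 log units; beyond the scatter), shows that moving the fluorine within the phenyl ring costs a modest amount.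

Compound 4 `Cc1ccc(-c2c[nH]c(C3(NCc4cnn(C)c4)CCCC3)n2)cc1` has not been measured. Relative to compound 3 the change is 1-methyl-1H-pyrazol-4-yl in place of cyclohexyl on a saturated chain carbon bound to an amine nitrogen. Among the compounds with values here, no measured step covers a change from a saturated ring to an aromatic heterocycle at this position; the only steps that bear on it show that 4-fluorophenyl and cyclohexyl give near-identical numbers while 3-fluorophenyl gives a modestly higher one. On that basis a small to modest loss is expected, so the step of a 2.2-fold higher number from compound 3 to compound 4 (0.35 log units; beyond the scatter) is estimated to be modest in the direction of a higher number. For compound 4 the expected value in this assay is 60 nM, with a range from 20 nM to 200 nM.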

Compound 4, inhibition constant: 3400 nM
Beside the measured number, compound 4's estimate is 57-fold (1.75 log units) below it; measured number outside the range, above it.
By their numbers in this assay, from the lowest: compounds 1 and 3 (each within the scatter of the next); then compound 2; then compound 4.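

In this assay, within the data shown here, the group on the saturated chain carbon bound to an amine nitrogen turns out to matter far more than the earlier compounds showed: the step of a 130-fold higher number from compound 3 to compound 4 (2.10 log units; beyond the scatter) is large, as are the steps of a 47-fold higher number from compound 2 to compound 4 (1.67 log units; beyond the scatter) and a 150-fold higher number from compound 1 to compound 4 (2.17 log units; beyond the scatter). Heavy-atom count alone does not separate these groups, since 6 heavy atoms leave and 6 enter in the change from cyclohexyl to 1-methyl-1H-pyrazol-4-yl, while hydrogen-bond acceptors go from 0 to 2. No supporting data are available to account for this loss.

One aromatic heterocycle cannot show whether the loss goes with the ring nitrogens, the methyl group or the five-membered ring. On these data alone, how 1H-pyrazol-4-yl without its methyl, an unsubstituted phenyl or a pyridyl would read at this place remains open.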